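The source may hold more compounds than are shown below. What is called first, only, known or untested is meant among the compounds shown, and "the series" means these compounds.

Measured compounds:
compound 1 `Cc1ccc2c(c1)CCC2NC(=O)Nc1cccc2[nH]ncc12`, 11 nM
compound 2 `O=C(Nc1cccc2[nH]ncc12)NC1CCc2cccnc21`, 1350 nM

In an assay on isolated protein for inhibition of transient receptor potential cation channel subfamily V member 1 (Homo sapiens), read by calcium flux (a lower number here means a stronger inhibitor, a higher number a weaker inhibitor), compound 1 gives 11 nM, the lowest of the two numbers at hand. Compound 2 gives 1350 nM in this assay, a much higher number that sits well beyond the usual scatter, so compound 1 stands clearly ahead of it.

Compound 3 `COc1ccc2c(c1)CCC2NC(=O)Nc1cccc2[nH]ncc12` has not yet been measured in this assay. It differs from compound 1 in one place: methoxy in place of methyl on an aromatic carbon. Among the compounds with values here, no measured pair shows the effect of this change on the shared core, so the expectation rests on compound 1 alone. The step is expected to be a 1.4-fold higher number from compound 1 to compound 3 (0.13 log units; within the scatter), no larger than the usual scatter, in either direction. Compound 3 is therefore expected to give about 15 nM in this assay, with a range from 5 nM to 50 nM.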

Compound 3, half-maximal inhibitory concentration: 40 nM
Estimate against measurement, compound 3: 2.7-fold (0.43 log units) below; the measured number falls inside the stated range.
By their numbers in this assay, from the lowest: compound 1; then compound 3; then compound 2.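

In this assay, within the data shown here, methoxy in place of methyl on this aromatic carbon gives a 3.6-fold higher number from compound 1 to compound 3 (0.56 log units; beyond the scatter), so the first direct comparison at this position shows that it is not indifferent to the change. The step is modest, which shows that this swap, with its one added oxygen, weakens inhibition without abolishing it. Nothing at hand explains the step.

With only methyl and methoxy compared on this carbon, the compounds shown cannot separate the effect of the oxygen from that of the larger group. They also leave open how a chlorine atom, an ethyl group or an ethoxy group would read at this same carbon, and whether any of these would match or improve on methyl.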